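This account rests on a few compounds, and the source may have more. Where it says the series, first, only, none or still open, it means among the compounds named here.

Series notes, cytotoxicity read-out on endothelial cells.

- compound 1 `Nc1nc(-c2ccccc2)cn1/N=C/c1cc2ccccc2nc1Cl` gives 46700 nM in an ADME assay on HUVEC cells (Homo sapiens) for cytotoxicity, read by MTT assay, with a stated time of 48 h; on this read-out higher numbers stand for weaker inhibition and lower numbers for stronger inhibition
- compound 2 `Cc1ccc2nc(Cl)c(/C=N/n3cc(-c4ccccc4)nc3N)cc2c1` gives 41500 nM in this assay
- compound 3 `Nc1nc(-c2ccc3ccccc3c2)cn1/N=C/c1cc2ccccc2nc1Cl` gives 36200 nM in this assay

Compound 2 holds the second highest of the three numbers. The step of a 1.1-fold lower number from compound 1 to compound 2 (0.05 log units; within the scatter) is within the scatter, and the gap from compound 2 to compound 3 is of the same small size, also within the scatter. All three numbers therefore sit together at weak inhibition.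

Compound 4 `Cc1ccc2nc(Cl)c(/C=N/n3cc(-c4cccc5ccccc45)nc3N)cc2c1` differs from compound 2 by naphthalen-1-yl in place of phenyl on an aromatic carbon of the five-membered aromatic ring with 2 nitrogen. Among the compounds with values here, the only measured single-site step, a 1.1-fold lower number from compound 1 to compound 2 (0.05 log units; within the scatter), concerns a methyl elsewhere and does not bear on this exchange. Compound 1 and compound 3 differ in the size of the aromatic group at this position, and their two values lie within the scatter of each other. No step beyond the scatter is therefore expected in this assay for compound 4.

Compound 4 is expected at 35000 nM, with a range of 17000 nM to 72000 nM. The expected step is a 1.2-fold lower number from compound 2 to compound 4 (0.07 log units; within the scatter).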

Compound 4, half-maximal inhibitory concentration: 9580 nM
The estimate for compound 4 lay 3.7-fold (0.56 log units) above the measured number; measured number outside the range, below it.
By their numbers in this assay, from the lowest: compound 4; then compounds 3, 2 and 1 (each within the scatter of the next).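

Within the data shown here, at this carbon of the five-membered aromatic ring, naphthalen-1-yl in place of phenyl gives a 4.3-fold lower number from compound 2 to compound 4 (0.64 log units; beyond the scatter) in this assay, the first single-site change to pass beyond the scatter. Size of the aromatic group alone does not account for this reading: compound 1 gives 46700 nM and compound 3, with a different larger aromatic group at this position, gives 36200 nM, so the position responds to some exchanges and barely to others. No measurement shown explains the step.

Compound 4 also carries the methyl absent from compound 3, so the compounds shown do not separate the way the naphthalene group is attached from any contribution of that methyl. From the compounds shown here alone, how a carboxylic acid or an aminomethyl group would read at this carbon also remains open.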